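Removing the dimethylsulfamoyl group from the aromatic nitrogen

The compounds below may be only part of what the source reports. "The series", "measured", "known", "first", "only" and "open" are said of these compounds alone.

Compound 1, `CCS(=O)(=O)Nc1cccc2c1CCCC2c1c[nH]cn1`, in an assay on isolated protein for binding affinity to Alpha-1D adrenergic receptor (Rattus norvegicus), read by radioligand binding (on this read-out lower numbers stand for stronger inhibition and higher numbers for weaker inhibition), gives 1070 nM.
Compound 2, `CC(=O)Nc1cccc2c1CCCC2c1c[nH]cn1`, in this assay gives only a limit, < 10000 nM.
Compound 3, `CN(C)S(=O)(=O)Nc1cccc2c1CCCC2c1c[nH]cn1`, in this assay gives 1580 nM.

Compound 3 has the highest of the two readable numbers; the nearest is compound 1, and the step of a 1.5-fold higher number from compound 1 to compound 3 (0.17 log units; within the scatter) does not leave the scatter. The third value is a limit, (the limit of < 10000 nM in this assay, at which 1 of the 3 values shown sits), so the steps a step that the limit leaves unreadable from compound 1 to compound 2 and a step that the limit leaves unreadable from compound 2 to compound 3 cannot be sized.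

Compound 4, `Nc1cccc2c1CCCC2c1c[nH]cn1`, differs from compound 3 in one place: hydrogen in place of dimethylsulfamoyl on a nitrogen on an aromatic ring. Among the measured compounds shown here, no measured step covers this change. For the measured compounds named here, the only readable step, a 1.5-fold higher number from compound 1 to compound 3 (0.17 log units; within the scatter), exchanges one substituent on the sulfonyl sulfur for another and keeps the sulfonamide; the steps involving compound 2 are unreadable. Whether the nitrogen substituent may be dropped altogether is therefore untested in this series, and the estimate rests on the size of what leaves. For compound 4 a higher number is expected in this assay, a step of a 3.2-fold higher number from compound 3 to compound 4 (0.50 log units; beyond the scatter). Compound 4 is estimated at 5000 nM, between 1500 nM and 15000 nM, with a real chance that only a limit is reported.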

Compound 4, inhibition constant: 191 nM
Compound 4: the middle estimate sits 26-fold (1.42 log units) above what was measured; measured number outside the range, below it.
By their numbers in this assay, from the lowest: compound 4; then compounds 1 and 3 (each within the scatter of the next).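

Among the compounds shown here, at the nitrogen on the aromatic ring, the plain amino group gives the first readable steps that lie beyond the scatter in this assay: an 8.3-fold lower number from compound 3 to compound 4 (0.92 log units; beyond the scatter), and a 5.6-fold lower number from compound 1 to compound 4 (0.75 log units; beyond the scatter). Changing the group on the sulfonyl sulfur had left the number within the scatter, whereas removing the whole sulfonyl substituent lowers it, so neither sulfonyl substituent is needed for binding in this assay. Compound 2 gives only a limit, so the steps that involve it cannot be read: the limit of < 10000 nM in this assay, at which 1 of the 4 values shown sits.

From the compounds shown here alone, whether a single methyl or a longer alkyl chain on this nitrogen keeps the lower number of compound 4 remains open. So does the effect of a urea at the same place.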